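Halogen swap on the aryl ketone core

The source may hold more compounds than are shown below. What is called first, only, known or untested is meant among the compounds shown, and "the series" means these compounds.

All three measured compounds were run in an assay on HL-60 cells for inhibition of glutathione S-transferase P (Homo sapiens); a lower number here means a stronger inhibitor, a higher number a weaker inhibitor.
compound 1 `C=C(C)C(=O)c1ccc(OCc2nc(-c3ccc(C(F)(F)F)cc3)no2)cc1Br` — 1300 nM
compound 2 `C=C(C)C(=O)c1ccc(OCc2nc(C)no2)cc1Cl` — 2100 nM
compound 3 `C=C(C)C(=O)c1ccc(OCc2nc(-c3ccc(C(F)(F)F)cc3)no2)cc1Cl` — 700 nM

From compound 3 to compound 1 the change is bromo in place of chloro on an aromatic carbon; it gave a 1.9-fold higher number from compound 3 to compound 1 (0.27 log units; within the scatter). Compound 2 differs from compound 3 in more than one place, and the difference between the two cores is not broken down here. Compound 4 `C=C(C)C(=O)c1ccc(OCc2nc(C)no2)cc1Br` is not yet measured. It differs from compound 2 by bromo in place of chloro on an aromatic carbon. This is the same kind of change as that from compound 3 to compound 1, though the surroundings read differently: in compound 2 the place is meta to a group of 8 heavy atoms, in compound 3 meta to a large group. For compound 4 the step is expected at a 1.6-fold higher number from compound 2 to compound 4 (0.20 log units; within the scatter) because a 1.9-fold higher number from compound 3 to compound 1 (0.27 log units; within the scatter) was seen for the same kind of change. Compound 4 is thus expected to give 3300 nM in this assay, between 1500 nM and 7000 nM.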

Compound 4, half-maximal inhibitory concentration: 3200 nM
Compound 4: middle estimate off by 1.0-fold (0.01 log units), on the high side, within the range that was stated.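

In this assay, bromo in place of chloro on an aromatic carbon gave a 1.5-fold higher number from compound 2 to compound 4 (0.18 log units; within the scatter). Set beside the earlier step on the core of compound 3, the change reads the same on both cores: the same change on two cores in this assay, a 1.9-fold higher number (0.27 log units; within the scatter) from compound 3 to compound 1 and a 1.5-fold higher number (0.18 log units; within the scatter) from compound 2 to compound 4, 1.2-fold (0.09 log units) apart, within the scatter of two such steps This shows that the swap carried over between these two cores with no difference that can be told apart, but each step lies within the scatter, so it does not show that bromo and chloro differ at this place, and two cores say nothing about any other core.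

Still open, from the compounds shown here alone, is whether a different group at this place, such as methoxy or nitrile, would give a step beyond the scatter. Also open, going by these compounds, is whether the swap reads the same on a core carrying an amine or a carboxylic acid.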